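This account rests on a few compounds, and the source may have more. Where it says the series, first, only, none or still open, it means among the compounds named here.

Measured compounds:
compound 1 `O=C(Nc1cccc(-n2cc(-c3ccncc3)c(-c3cc(O)cc(Cl)c3)n2)c1)Nc1ccc(Cl)c(C(F)(F)F)c1`, -85%
compound 2 `O=C(Nc1cccc(-n2cc(-c3ccncc3)c(-c3cc(O)cc(Cl)c3)n2)c1)Nc1ccc(Cl)c(Cl)c1`, -74%

Both compounds were tested in a functional assay on UACC-62 cells (Homo sapiens) for inhibition, read by sulforhodamine B assay, with a stated time of 48 h, tested at 100 uM; a higher number here means a weaker effect of the compound at the concentration tested, a lower number a stronger effect. Compound 1 gives -85%, the lowest of the two numbers, and compound 2 stands nearest to it at -74%. Going by the values given here, the single measured step, a number 11 percentage points higher from compound 1 to compound 2 (beyond the scatter), comes with a chloro in place of a trifluoromethyl on an aromatic carbon and is modest, though beyond the usual scatter.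

Compound 3 `COc1cc(Cl)cc(-c2nn(-c3cccc(NC(=O)Nc4ccc(Cl)c(C(F)(F)F)c4)c3)cc2-c2ccncc2)c1` is not yet measured in this assay. It differs from compound 1 by methyl in place of hydrogen on an oxygen on an aromatic ring, a methyl in place of hydrogen on an oxygen on an aromatic ring, so that the 3-chloro-5-hydroxyphenyl becomes a 3-chloro-5-methoxyphenyl. Neither measured step touches this part of the shared core; the step from compound 1 to compound 2 concerns a different aromatic carbon and therefore gives no direct guide. Among the compounds with values here, with no bearing step available, the expectation rests on the nearest compound alone: the step of a number 7 percentage points higher from compound 1 to compound 3 (within the scatter) is expected to stay within or near the scatter, with no clear direction. Compound 3 is estimated at -78%, between -95% and -50%.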

Compound 3, a percentage reported as activity, at one concentration (the size of the read-out at that concentration, not a potency): -85%
Compound 3: the middle estimate sits 7 percentage points above what was measured; low and high end bracket the measured number.
By their numbers in this assay, from the lowest: compounds 1 and 3 (each within the scatter of the next); then compound 2.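

In this assay, going by these compounds alone, the change from hydroxy to methoxy, a methyl in place of hydrogen on an oxygen on an aromatic ring, brings no change at the digits printed from compound 1 to compound 3 (within the scatter) and gives the first reading at this position, which the earlier step did not touch. For this one pair, the hydrogen on that oxygen is therefore not required for the effect seen at the tested concentration, and the 3-chloro-5-methoxyphenyl serves as well as the 3-chloro-5-hydroxyphenyl within the scatter. Nothing available here explains this outcome, so the observation stands without any measured account behind it.

Going by these compounds, it remains open whether a larger group on this oxygen, such as an ethoxy or a longer chain, or an amine or a carboxylic acid in place of the hydroxy, would leave the read-out equally unchanged. On these data alone, it also remains open whether the same change would give a similar step on compound 2, and whether the two compounds of this pair would stay level at concentrations other than the single one tested.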